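Sulfonyl hydrazide series: cell toxicity on SK-OV-3

This account rests on a few compounds, and the source may have more. Where it says the series, first, only, none or still open, it means among the compounds named here.

Compound 1 `CC(=O)Nc1ccc(S(=O)(=O)NNC(=O)c2cccnc2Nc2ccc(Cl)cc2)cc1`: > 100000 nM
Compound 2 `O=C(NNS(=O)(=O)c1ccc(F)cc1)c1cccnc1Nc1ccc(Cl)cc1Cl`: > 100000 nM
Compound 3 `O=C(NNS(=O)(=O)c1ccc(Cl)cc1Cl)c1cccnc1Nc1ccc(Cl)cc1`: to be measured

In a functional assay on SK-OV-3 cells (Homo sapiens) for antiproliferative activity (on this read-out lower numbers stand for higher toxicity in this test and higher numbers for lower toxicity in this test), compound 1 gives > 100000 nM, which is a limit of the test and not a number. Compound 2 likewise gives only a limit, > 100000 nM. Among the compounds with values here, compound 1 therefore stands at the edge of what the test reports, and so does the one other compound measured alongside it (the limit of > 100000 nM in this assay, at which 2 of the 2 values shown sit).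

The change to compound 3 is 2,4-dichlorophenyl in place of 4-acetamidophenyl on a sulfonyl sulfur. Within the data shown here, since both measured compounds sit at the same limit, no step between measured compounds can be sized here; the two values together show only that neither reached a measurable concentration.

The expectation for compound 3 is no step beyond the scatter in this assay, a number no higher from compound 1 to compound 3 (the limit leaves the size open), with a fair chance that only a limit is reported again. Compound 3 is estimated at 100000 nM, within 30000 nM to 300000 nM.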

Compound 3, concentration lethal to 50% of the cells: > 100000 nM
Compound 3 gave a limit, no number; the forecaster's own chance of this, stated with the estimate: 75%; the middle value sits exactly at the limit.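

In this assay compound 3 gives > 100000 nM, which is a limit and not a number. No step from compound 1 to compound 3 can be read, as both stand at the same limit: the limit of > 100000 nM in this assay, at which 3 of the 3 values shown sit.

The compounds shown leave open whether any change on a sulfonyl sulfur would give a measurable number in this assay.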